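Aminophenyl in place of dimethoxyphenyl: an expected large loss

A few compounds are considered here, and "the series" means these few. Any claim that something is new, unique, unknown or untested is made for them only; others in the source may bear on it.

Measured in a functional assay on HL-60 cells (Homo sapiens) for cytotoxicity, read by MTT assay, with a stated time of 72 h; on this read-out lower numbers stand for stronger inhibition and higher numbers for weaker inhibition:
compound 1 `COc1cc(Nc2nc3ccccc3nc2S(=O)(=O)c2ccccc2)cc(OC)c1` gives 50 nM;
compound 2 `Nc1ccc(Nc2nc3ccccc3nc2S(=O)(=O)c2ccccc2)cc1` gives 8720 nM;
compound 3 `COc1cc(Nc2nc3ccccc3nc2S(=O)(=O)c2ccc(C)cc2)cc(OC)c1` gives 20 nM.

Compound 4 `Cc1ccc(S(=O)(=O)c2nc3ccccc3nc2Nc2ccc(N)cc2)cc1` has not yet been measured. The cores of compound 1 and compound 3 differ in one place, (methyl in place of hydrogen on an aromatic carbon), and this change made a 2.5-fold lower number from compound 1 to compound 3 (0.40 log units; beyond the scatter). Compound 4 differs from compound 3 by 4-aminophenyl in place of 3,5-dimethoxyphenyl on a nitrogen on an aromatic ring. The change from compound 1 to compound 2 is 4-aminophenyl in place of 3,5-dimethoxyphenyl on a nitrogen on an aromatic ring; its place reads the same word for word, so this is the same change, and it made a 170-fold higher number from compound 1 to compound 2 (2.24 log units; beyond the scatter). The step from compound 3 to compound 4 is expected to be of similar size, a 170-fold higher number from compound 3 to compound 4 (2.23 log units; beyond the scatter), resting on that large measured step. Compound 4 is estimated at 3400 nM, expected between 1200 nM and 10000 nM.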

Compound 4, half-maximal inhibitory concentration: 1220 nM
Estimate against measurement, compound 4: 2.8-fold (0.45 log units) above; measured number inside the range.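

In this assay, 4-aminophenyl in place of 3,5-dimethoxyphenyl again brings a large loss, with a 61-fold higher number from compound 3 to compound 4 (1.79 log units; beyond the scatter), but the size of the step differs between the two cores: the same change on two cores in this assay, a 170-fold higher number (2.24 log units; beyond the scatter) from compound 1 to compound 2 and a 61-fold higher number (1.79 log units; beyond the scatter) from compound 3 to compound 4, 2.9-fold (0.46 log units) apart, beyond the scatter of two such steps. The methyl step also keeps its direction, with a 7.1-fold lower number from compound 2 to compound 4 (0.85 log units; beyond the scatter), and its size likewise differs between the two cores: the same change on two cores in this assay, a 2.5-fold lower number (0.40 log units; beyond the scatter) from compound 1 to compound 3 and a 7.1-fold lower number (0.85 log units; beyond the scatter) from compound 2 to compound 4, 2.9-fold (0.46 log units) apart, beyond the scatter of two such steps. Each change therefore carried over in direction but not in size, and these compounds do not show the reason for the difference or how either change would behave on any further core. The compounds shown leave open whether a chlorine atom or a methoxy group in place of the methyl would follow the same pattern. They also leave open what a pyridine ring in place of the 4-aminophenyl would do.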